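Exchanging the Phenyl Group on the Ring Nitrogen

A few compounds are considered here, and "the series" means these few. Any claim that something is new, unique, unknown or untested is made for them only; others in the source may bear on it.

Three compounds sharing one core were measured in a functional assay on CHO cells with adenosine receptor A1 (Homo sapiens) as the target, read by cAMP accumulation and immunoassay, with a stated time of 6 min, tested at 0.01 uM; on this read-out lower numbers stand for a stronger effect and higher numbers for a weaker effect at the one concentration tested. Compound 1 `Nc1scc(CN2CCN(c3ccc(Cl)cc3F)CC2)c1C(=O)c1ccc(Cl)cc1` gives -9.2%. Compound 2 `Nc1scc(CN2CCN(c3ccc(Cl)c(C(F)(F)F)c3)CC2)c1C(=O)c1ccc(Cl)cc1` gives -2.5%. Compound 3 `Nc1scc(CN2CCC(c3ccc(Cl)cc3)CC2)c1C(=O)c1ccc(Cl)cc1` gives 0%. Compound 2 stands second highest of the three numbers; its nearest neighbour is compound 3 and its furthest is compound 1, both within the scatter. Within the data shown here, the only measured step between compounds that differ in one place, a number 6.7 percentage points higher from compound 1 to compound 2 (within the scatter), is within the scatter, so nothing seen so far moves the read-out beyond noise.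

Compound 4 `Nc1scc(CN2CCN(c3cc(F)cc(F)c3)CC2)c1C(=O)c1ccc(Cl)cc1` has not yet been measured. It differs from compound 2 by 3,5-difluorophenyl in place of 4-chloro-3-(trifluoromethyl)phenyl on an amine nitrogen in a ring. Among the measured compounds shown here, the one step that bears on this change, a number 6.7 percentage points higher from compound 1 to compound 2 (within the scatter), was small, and compound 3 gives a number in the same span. The step of a number 0.5 percentage points lower from compound 2 to compound 4 (within the scatter) is therefore expected to lie within the scatter. Compound 4 is estimated at -3% in this assay, with a range from -13% to 7%.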

Compound 4, a percentage reported as activity, at one concentration (the size of the read-out at that concentration, not a potency): -13%
Beside the measured number, compound 4's estimate is 10 percentage points above it; low and high end bracket the measured number.
By their numbers in this assay, from the lowest: compounds 4, 1, 2 and 3 (each within the scatter of the next, the first and the last beyond it).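

In this assay, among these compounds, 3,5-difluorophenyl in place of 4-chloro-3-(trifluoromethyl)phenyl gives a number 10.5 percentage points lower from compound 2 to compound 4 (beyond the scatter), the first step at this amine nitrogen to pass beyond the scatter, so the choice of aryl group here can shift the read-out towards a stronger effect. The change from 4-chloro-2-fluorophenyl to the same 3,5-difluorophenyl, a number 3.8 percentage points lower from compound 1 to compound 4 (within the scatter), does not separate the two compounds, so the shift is seen against only one of the two earlier groups. Nothing available accounts for the step.

The exchange from compound 2 to compound 4 alters the chlorine, the trifluoromethyl and the fluorines together, leaving open which of them matters. Also open, on these data alone, is how a phenyl group carrying a methoxy group or a nitrile, or an unsubstituted phenyl, would read on this nitrogen.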